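Series notes: compound 3 projected from compounds 1 and 2

The source may hold more compounds than are shown below. What is called first, only, known or untested is meant among the compounds shown, and "the series" means these compounds.

Measured so far:
compound 1 `CN(C)C/C=C/C(=O)Nc1cccc(Nc2nc(N/N=C/c3ccc(F)cc3)ncc2Cl)c1`: 3300 nM
compound 2 `C/C(=N\Nc1ncc(Cl)c(Nc2cccc(NC(=O)/C=C/CN(C)C)c2)n1)c1ccc(C)cc1`: 11800 nM

In an ADME assay on HT-29 cells (Homo sapiens) for inhibition, read by MTT assay, with a stated time of 72 h (on this read-out lower numbers stand for stronger inhibition and higher numbers for weaker inhibition), compound 2 gives 11800 nM, the highest of the two numbers; its nearest neighbour is compound 1, with a 3.6-fold higher number from compound 1 to compound 2 (0.55 log units; beyond the scatter). Compound 3 `C/C(=N\Nc1ncc(Cl)c(Nc2cccc(NC(=O)/C=C/CN(C)C)c2)n1)c1ccncc1` differs from compound 2 by pyridin-4-yl in place of 4-methylphenyl on a carbon with a double bond to nitrogen. Among the measured compounds shown here, the single measured step, a 3.6-fold higher number from compound 1 to compound 2 (0.55 log units; beyond the scatter), concerns a ring exchange on the nitrogen on an aromatic ring, not on the carbon with a double bond to nitrogen, so it only sets a modest scale for ring swaps here. Compound 3 is therefore expected at 8000 nM, within 2500 nM to 25000 nM, the expected step of a 1.5-fold lower number from compound 2 to compound 3 (0.17 log units; within the scatter) being small and of uncertain direction.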

Compound 3, half-maximal inhibitory concentration: 10900 nM
Compound 3: the middle estimate sits 1.4-fold (0.13 log units) below what was measured, within the range that was stated.
By their numbers in this assay, from the lowest: compound 1; then compounds 3 and 2 (each within the scatter of the next).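

In this assay, pyridin-4-yl in place of 4-methylphenyl on the carbon with a double bond to nitrogen gives a 1.1-fold lower number from compound 2 to compound 3 (0.03 log units; within the scatter), so this ring exchange, with its added hydrogen-bond acceptor, shows no change beyond the scatter. The other new step, a 3.3-fold higher number from compound 1 to compound 3 (0.52 log units; beyond the scatter), replaces the whole group on the nitrogen on an aromatic ring, so it cannot assign the difference to any one part of that group. No available measurement explains either step. Still open, from the compounds shown here alone, is whether an amine or a carboxylic acid in place of pyridin-4-yl on that carbon would shift the number beyond the scatter.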